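A few compounds are considered here, and "the series" means these few. Any claim that something is new, unique, unknown or untested is made for them only; others in the source may bear on it.

Compound 1 `O=c1nc(N2CC[C@H](c3ccccc3)[C@@H](O)C2)sc2c([N+](=O)[O-])cc(C(F)(F)F)cc12` and compound 2 `N#Cc1ccccc1N1CCN(c2nc(=O)c3cc(C(F)(F)F)cc([N+](=O)[O-])c3s2)CC1` share a common core and were both examined in an ADME assay on microsomes from liver (Homo sapiens) for metabolic stability, with a stated time of 90 min, tested at 20 uM; a lower number here means that the compound disappears faster, a higher number that the compound lasts longer. In this assay compound 1 gives 0.875 h. Compound 2 gives 1.65 h, and this number and that of compound 1 lie within the usual scatter of each other, so the two compounds cannot be told apart on the half-life data shown. Compound 3 `N#Cc1cccc(CN2CCN(c3nc(=O)c4cc(C(F)(F)F)cc([N+](=O)[O-])c4s3)CC2)c1` is the next case; it differs from compound 2 by 3-cyanobenzyl in place of 2-cyanophenyl on an amine nitrogen in a ring. Among the compounds with values here, no measured pair of this series shows what such a change does. The expectation is that the step from compound 2 to compound 3 in this assay, a 1.7-fold lower number from compound 2 to compound 3 (0.22 log units; within the scatter), will be small, probably within the scatter and if anything toward a shorter half-life. The half-life of compound 3 is therefore estimated at 1 h, with a range from 0.4 h to 2.5 h.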

Compound 3, half-life: 1 h
For compound 3 middle estimate and measured number coincide at the digits printed, and the stated range covers the measured number.
By their numbers in this assay, from the lowest: compounds 1, 3 and 2 (each within the scatter of the next).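

Within the data shown here, the exchange of 2-cyanophenyl for 3-cyanobenzyl on the amine nitrogen in the ring gives the first comparison of compounds that differ in one place, and this assay shows a 1.7-fold lower number from compound 2 to compound 3 (0.22 log units; within the scatter). At this position, then, the half-life does not separate the two groups, although the exchange alters both the link to the ring nitrogen and the place of the nitrile. Nothing available bears on the reason for this result.

Open, as far as these compounds go, is which of those two alterations counts, something that 3-cyanophenyl or 2-cyanobenzyl on the same nitrogen could separate. Also open, from the compounds shown here alone, is whether a plain benzyl group, or a carboxylic acid in place of the nitrile, would move the half-life beyond the scatter.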